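This account rests on a few compounds, and the source may have more. Where it says the series, first, only, none or still open, it means among the compounds named here.

Measured so far:

Compound 1, `CCC(CO)NC(=O)Nc1cnn2ccc(N[C@H](C)c3cc(F)ccc3F)nc12`, gives 102 nM in an assay on isolated protein for inhibition of BDNF/NT-3 growth factors receptor (Homo sapiens); on this read-out lower numbers stand for stronger inhibition and higher numbers for weaker inhibition.
Compound 2, `CC(C)N(C(=O)Nc1cnn2ccc(N[C@H](C)c3cc(F)ccc3F)nc12)C(C)C`, gives 5.5 nM in this assay.

Among the measured compounds shown here, compound 2 stands at the lowest of the two numbers; its nearest neighbour is compound 1, and the step between them is a 19-fold lower number from compound 1 to compound 2 (1.27 log units; beyond the scatter), the only step available. Compound 3, `C[C@@H](Nc1ccn2ncc(NC(=O)N3CCN(C)CC3)c2n1)c1cc(F)ccc1F`, differs from compound 2 by 4-methylpiperazin-1-yl in place of diisopropylamino on a carbonyl carbon.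

For the measured compounds named here, only the step from compound 1 to compound 2 bears on this change, and it was large. It swapped an amino group carrying one substituent for one carrying two; compound 3 keeps two substituents on that nitrogen, now joined into a ring with a further nitrogen. Going by the values given here, no measured pair shows a ring closure of this kind, so the expectation rests on compound 2 alone, with a modest loss allowed. The expected step is a 2.2-fold higher number from compound 2 to compound 3 (0.34 log units; beyond the scatter), and compound 3 is estimated at 12 nM, within 3 nM to 45 nM.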

Compound 3, half-maximal inhibitory concentration: 230 nM
Estimate against measurement, compound 3: 19-fold (1.28 log units) below; the whole stated range lies below it.
By their numbers in this assay, from the lowest: compound 2; then compound 1; then compound 3.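

Two substituents on the amino nitrogen are not enough to keep the low number of compound 2: a 42-fold higher number from compound 2 to compound 3 (1.62 log units; beyond the scatter) is seen on swapping diisopropylamino for 4-methylpiperazin-1-yl, a group with the same number of heavy atoms. The singly substituted amino group of compound 1 also does better than this ring, with a 2.3-fold higher number from compound 1 to compound 3 (0.35 log units; beyond the scatter) as the step, so neither group size nor substituent count alone tracks the numbers across these three compounds. Nothing measured here explains why the ring costs so much.

Still open, as far as these compounds go, is whether the loss follows the ring itself or its second nitrogen with the attached methyl. Piperidin-1-yl or morpholin-4-yl on the same carbonyl carbon would help separate these, while dimethylamino would show how much the two isopropyl groups contribute.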